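This account rests on a few compounds, and the source may have more. Where it says the series, first, only, none or still open, it means among the compounds named here.

In a functional assay on L1210 cells (Mus musculus) (on this read-out higher numbers stand for weaker inhibition and lower numbers for stronger inhibition), compound 1 `CCc1cn([C@H]2C[C@@H]3OP(=O)(O)OC[C@H]3O2)c(=O)[nH]c1=O` gives 55 ug/mL. Compound 2 `CCCCCCc1cn([C@H]2C[C@@H]3OP(=O)(O)OC[C@H]3O2)c(=O)[nH]c1=O` reaches only a limit of the assay, > 500 ug/mL. Compound 3 `CC(C)c1cn([C@H]2C[C@@H]3OP(=O)(O)OC[C@H]3O2)c(=O)[nH]c1=O` likewise reaches only a limit, > 500 ug/mL, so where it stands is known only through (the limit of > 500 ug/mL in this assay, at which 2 of the 3 values shown sit). The change to compound 4 `CCCCCc1cn([C@H]2C[C@@H]3OP(=O)(O)OC[C@H]3O2)c(=O)[nH]c1=O` is pentyl in place of isopropyl on an aromatic carbon. For the measured compounds named here, two measured steps bear on it: an at least 9.0-fold higher number from compound 1 to compound 2 (0.95 log units; beyond the scatter) and an at least 9.0-fold higher number from compound 1 to compound 3 (0.95 log units; beyond the scatter), both lengthening or branching the chain and both weakening inhibition. The step that the two limits leave unreadable from compound 2 to compound 3 cannot be read. Pentyl lies between ethyl and hexyl in length. Given an at least 9.0-fold higher number from compound 1 to compound 2 (0.95 log units; beyond the scatter), compound 4 is expected to show a number no higher from compound 3 to compound 4 (the limit leaves the size open), no change beyond the scatter. Compound 4 is estimated at 500 ug/mL, within 150 ug/mL to 2000 ug/mL.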

Compound 4, concentration for 50% inhibition: > 500 ug/mL
Compound 4: a limit, no number; the forecaster's own chance of this, stated with the estimate: 65%; the middle value lies on the limit itself.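

In this assay there is an at least 9.0-fold higher number from compound 1 to compound 4 (0.95 log units; beyond the scatter), so the pentyl chain on this aromatic carbon weakens inhibition relative to the ethyl of compound 1, as hexyl and isopropyl did. Compound 4 gives > 500 ug/mL, which is a limit and not a number. The steps among compound 2, compound 3 and compound 4 cannot be read, so these groups cannot be put in any order: the limit of > 500 ug/mL in this assay, at which 3 of the 4 values shown sit.

Still open, from the compounds shown here alone, is whether a methyl group, or a short chain ending in an amine or a hydroxyl group, at this place would give a lower number than compound 1.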